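The source may hold more compounds than are shown below. What is called first, only, known or untested is meant among the compounds shown, and "the series" means these compounds.

In a functional assay on the whole organism (Tail, strain ICR) with Mus musculus as the target, in the tail flick test, with a stated time of 90 min, at a dose of 25 umol/kg by the oral route (a higher number here means a stronger effect of the compound at the dose given, a lower number a weaker effect), three compounds have been measured: compound 1 `O=C(O)CC[C@H](NC(=O)CN(c1nc(Cl)nc2[nH]cnc12)C1CC1)C(=O)O` gives 44.7%; compound 2 `NC(=O)C[C@H](NC(=O)CN(c1nc(Cl)nc2[nH]cnc12)C1CC1)C(=O)OCc1ccccc1` gives 32.3%; compound 3 `NC(=O)CC[C@H](NC(=O)CN(c1nc(Cl)nc2[nH]cnc12)C1CC1)C(=O)OCc1ccccc1` gives 42.8%.

Compound 1 stands highest of the three numbers, though compound 3 lies within the scatter of it; only compound 2 sits beyond the scatter below it. Compound 4 `O=C(CN(c1nc(Cl)nc2[nH]cnc12)C1CC1)N[C@@H](CO)C(=O)O` differs from compound 1 by hydroxy in place of carboxymethyl on a saturated chain carbon, two bonds along the chain from an amide-type nitrogen and a carbonyl carbon. Among the compounds with values here, no measured step reproduces this change. The nearest guide is a number 10.5 percentage points higher from compound 2 to compound 3 (beyond the scatter), where one chain carbon fewer on the same side chain went with the lower number. Compound 4 removes more than one carbon and the second carboxyl, so a modest fall is expected: a number 11.7 percentage points lower from compound 1 to compound 4 (beyond the scatter). The estimate for compound 4 is 33%, within 18% to 48%.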

Compound 4, a percentage reported as activity, at one dose (the size of the read-out at that dose, not a potency): 43.9%
Beside the measured number, compound 4's estimate is 10.9 percentage points below it; the measured number falls inside the stated range.
By their numbers in this assay, from the lowest: compound 2; then compounds 3, 4 and 1 (each within the scatter of the next).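

The step of a number 0.8 percentage points lower from compound 1 to compound 4 (within the scatter) in this assay shows that, at this place, hydroxy can stand in place of carboxymethyl without a change beyond the scatter, so the carboxylic acid of that side chain is not needed for this read-out at this dose. The earlier step of a number 10.5 percentage points higher from compound 2 to compound 3 (beyond the scatter) had suggested sensitivity to side-chain length, but that did not carry over to this different change. Nothing available explains the result.

Going by these compounds, whether an amine or a longer chain ending in hydroxy at this place would behave the same stays open.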